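A few compounds are considered here, and "the series" means these few. Any claim that something is new, unique, unknown or untested is made for them only; others in the source may bear on it.

Measured so far:
compound 1, `CC(C)[C@H](NC(=O)COc1cccc2ccccc12)C(=O)N[C@@H](CC(=O)O)C(=O)CSc1ncc[nH]1`: in a functional assay on Jurkat cells (Homo sapiens) for inhibition (a lower number here means a stronger inhibitor, a higher number a weaker inhibitor), compound 1 gives > 200000 nM, which is a limit of the assay and not a number.
compound 2, `CC(C)[C@H](NC(=O)COc1cccc2ccccc12)C(=O)N[C@@H](CC(=O)O)C(=O)COc1ccnc(C(F)(F)F)n1`: in this assay compound 2 gives 37000 nM.

Going by the values given here, compound 2 therefore holds the only actual number here; compound 1 sits at the limit of > 200000 nM in this assay, at which 1 of the 2 values shown sits. Among the compounds with values here, the single measured step, an at least 5.4-fold lower number from compound 1 to compound 2 (0.73 log units; beyond the scatter), swapped one whole ring system for a different one. Compound 3, `CC(C)[C@H](NC(=O)COc1cccc2ccccc12)C(=O)N[C@@H](CC(=O)O)C(=O)COc1cc(C(F)(F)F)ncn1`, keeps every atom of compound 2 and only moves the trifluoromethyl to another spot on the same ring: 6-(trifluoromethyl)pyrimidin-4-yl in place of 2-(trifluoromethyl)pyrimidin-4-yl on an oxygen on a saturated carbon. Within the data shown here, no measured step shifts a group within a ring, so the one step available bears on this change only loosely and gives no direction. Compound 3 is expected to give about 37000 nM, with a range of 12000 nM to 110000 nM. The expected step, no change at the digits printed from compound 2 to compound 3 (within the scatter), is not expected to rise beyond the scatter.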

Compound 3, half-maximal inhibitory concentration: > 200000 nM
Compound 3: no number, only a limit; the forecaster's own chance of this, stated with the estimate: 15%; middle value at least 5.4-fold (0.73 log units) from the limit.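

With the same atoms joined differently, 6-(trifluoromethyl)pyrimidin-4-yl in place of 2-(trifluoromethyl)pyrimidin-4-yl gives an at least 5.4-fold higher number from compound 2 to compound 3 (0.73 log units; beyond the scatter). The earlier step exchanged one whole ring system for another, whereas this one shows that in this assay the pyrimidine ring alone does not secure a measurable value: where the trifluoromethyl sits on it matters too. Compound 1 and compound 3 each carry a limit of the assay and not a number, so the step between them cannot be read: the limit of > 200000 nM in this assay, at which 2 of the 3 values shown sit.

As far as these compounds go, how far compound 3 lies past its limit remains unknown. Also open, from the compounds shown here alone, is whether an amine or a nitrile in place of the trifluoromethyl of 2-(trifluoromethyl)pyrimidin-4-yl would keep or improve on compound 2 at 37000 nM.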